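A few compounds are considered here, and "the series" means these few. Any claim that something is new, unique, unknown or untested is made for them only; others in the source may bear on it.

Measured so far in an assay on HEK293 cells for displacement of a labelled ligand from growth hormone secretagogue receptor type 1 (Homo sapiens), with a stated time of 8 h; on this read-out lower numbers stand for stronger inhibition and higher numbers for weaker inhibition:
compound 1 `COc1ccc(OCC(=O)N2CCC3(CC2)CN(Cc2ccc(OCC(C)C)cc2Cl)C3)cc1` — 86 nM
compound 2 `COc1ccc(OCC(=O)N2CCC3(CC2)CN(Cc2ccc(-c4nnc(C)o4)cc2)C3)cc1` — 1070 nM
compound 3 `COc1ccc(OCC(=O)N2CCC3(CC2)CN(Cc2ccc(-n4cccn4)cc2)C3)cc1` — 442 nM

Compound 3 stands second highest of the three numbers in this assay. Its nearest neighbour is compound 2, with a higher number; the furthest is compound 1, with the lowest number in the set.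

Compound 4 `COc1ccc(OCC(=O)N2CCC3(CC2)CN(Cc2ccc(-n4nccn4)cc2)C3)cc1` has not yet been measured. It differs from compound 3 in one place: 2H-1,2,3-triazol-2-yl in place of 1H-pyrazol-1-yl on an aromatic carbon.

Going by the values given here, only one measured step concerns a swap of the five-membered aromatic ring on the same aromatic carbon: a 2.4-fold lower number from compound 2 to compound 3 (0.38 log units; beyond the scatter). That step exchanged a ring with a carbon link for one with a nitrogen link and was modest in size. Among the compounds with values here, no measured pair exchanges one nitrogen-linked five-membered ring for another, so nothing directly tells how adding a third ring nitrogen shifts this assay. With so little to rest on, the expectation for compound 4 in this assay is a step of no clear direction beyond the scatter, a 1.1-fold higher number from compound 3 to compound 4 (0.05 log units; within the scatter). The estimate for compound 4 is therefore 500 nM, with a range from 200 nM to 1300 nM; the wide range reflects that compound 3 at 442 nM is the only anchor.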

Compound 4, half-maximal inhibitory concentration: 102 nM
For compound 4 the middle estimate is 4.9-fold (0.69 log units) above the measured one, outside the stated range (below it).
By their numbers in this assay, from the lowest: compounds 1 and 4 (each within the scatter of the next); then compound 3; then compound 2.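

In this assay the identity of the five-membered aromatic ring on this carbon, para to a large group, matters even between two nitrogen-linked rings of 5 heavy atoms: 2H-1,2,3-triazol-2-yl in place of 1H-pyrazol-1-yl gives a 4.3-fold lower number from compound 3 to compound 4 (0.64 log units; beyond the scatter) and this modest step lies beyond the scatter. The earlier pair had changed the linking atom as well, whereas here the link stays nitrogen and one ring carbon becomes a ring nitrogen, so the linking atom alone does not set the level at this position. Across the three rings the span is now large, with a 10-fold lower number from compound 2 to compound 4 (1.02 log units; beyond the scatter) as the full width, and the order in this small set runs from 2H-1,2,3-triazol-2-yl through 1H-pyrazol-1-yl to 5-methyl-1,3,4-oxadiazol-2-yl; no measurement available here accounts for that order.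

Open, from the compounds shown here alone, is whether the ring nitrogen arrangement or their number drives the step, which a 1H-1,2,3-triazol-1-yl, a 1H-imidazol-1-yl or a 2H-tetrazol-2-yl group at the same place would help separate. Also open, going by these compounds, is whether the gain from 2H-1,2,3-triazol-2-yl carries over when the chlorine seen in compound 1 is present on the same aromatic ring.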